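The compounds below may be only part of what the source reports. "The series", "measured", "known", "first", "only" and "open" are said of these compounds alone.

Measured in a functional assay on Jurkat cells for inhibition of nuclear factor NF-kappa-B complex (Homo sapiens); on this read-out lower numbers stand for stronger inhibition and higher numbers for weaker inhibition:
compound 1 `CCOC(=O)c1cnc(C)nc1NN1C(=O)C=C(C)C1=O` gives 16000 nM
compound 2 `CCOC(=O)c1cnc(SC)nc1NN1C(=O)C=C(C)C1=O` gives 200 nM
compound 3 `CCOC(=O)c1cnc(-c2cnc3ccccc3c2)nc1NN1C(=O)C=C(C)C1=O` gives 6000 nM

Compound 3 sits second highest of the three: a 2.7-fold lower number from compound 1 to compound 3 (0.43 log units; beyond the scatter), while a 30-fold higher number from compound 2 to compound 3 (1.48 log units; beyond the scatter). Compound 4 `CCOC(=O)c1cnc(-c2cccc(OC)c2)nc1NN1C(=O)C=C(C)C1=O` differs from compound 3 in one place: 3-methoxyphenyl in place of quinolin-3-yl on an aromatic carbon. For the measured compounds named here, no measured step swaps one aryl group for another; the only steps known touch the quinolin-3-yl against methyl, a 2.7-fold lower number from compound 1 to compound 3 (0.43 log units; beyond the scatter), and against methylsulfanyl, a 30-fold higher number from compound 2 to compound 3 (1.48 log units; beyond the scatter), and methyl against methylsulfanyl, an 80-fold lower number from compound 1 to compound 2 (1.90 log units; beyond the scatter). Both aryl groups are of comparable size, so in this assay no step beyond the scatter is expected: a 1.2-fold lower number from compound 3 to compound 4 (0.08 log units; within the scatter). Compound 4 is therefore estimated at 5000 nM, within 1500 nM to 16000 nM.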

Compound 4, half-maximal inhibitory concentration: 5000 nM
The estimate for compound 4 equals the measured number at the digits printed; measured number inside the range.
By their numbers in this assay, from the lowest: compound 2; then compounds 4 and 3 (each within the scatter of the next); then compound 1.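

In this assay, 3-methoxyphenyl in place of quinolin-3-yl on the aromatic carbon between two ring nitrogen atoms changes nothing beyond the scatter: a 1.2-fold lower number from compound 3 to compound 4 (0.08 log units; within the scatter); removing one aromatic ring from the aryl group therefore leaves the number in the same range. The methylsulfanyl group stays well apart from this second aryl group, a 25-fold higher number from compound 2 to compound 4 (1.40 log units; beyond the scatter), whereas the difference from methyl remains modest, a 3.2-fold lower number from compound 1 to compound 4 (0.51 log units; beyond the scatter). No available evidence accounts for these differences. From the compounds shown here alone, whether an ethylsulfanyl group or an amine at this position would match methylsulfanyl remains open.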